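Benzyl for Cyclopropyl on a Fluoronaphthyl Pyridinone Scaffold

A few compounds are considered here, and "the series" means these few. Any claim that something is new, unique, unknown or untested is made for them only; others in the source may bear on it.

Measured compounds:
compound 1, `O=C1NC(=O)/C(=C/C(c2ccc(-c3ccc4cccc(F)c4c3)[nH]c2=O)C2CC2)O1`, 1.98 h
compound 2, `CC(C)[C@H](C[C@@H]1OC(=O)NC1=O)c1ccc(-c2ccc3cccc(F)c3c2)[nH]c1=O`, 2.07 h

In an ADME assay on microsomes from liver (Homo sapiens) for metabolic stability (on this read-out higher numbers stand for a longer-lived compound and lower numbers for a shorter-lived compound), compound 1 gives 1.98 h. Compound 2 gives 2.07 h in this assay, and on the numbers shown compound 1 and compound 2 sit within the scatter of each other, so neither can be told apart from the other. Compound 3, `O=C1NC(=O)/C(=C/C(Cc2ccccc2)c2ccc(-c3ccc4cccc(F)c4c3)[nH]c2=O)O1`, has not yet been measured. It differs from compound 1 in one place: benzyl in place of cyclopropyl on a saturated chain carbon bound to an aromatic carbon and a double-bonded chain carbon. Going by the values given here, no measured pair in this set shows this change, so there is no step to lean on. The two measured numbers give a flat picture around the shared core. Compound 3 is expected to come out a little shorter-lived, with a step of a 1.3-fold lower number from compound 1 to compound 3 (0.12 log units; within the scatter) that may not clear the scatter. The estimate for compound 3 in this assay is 1.5 h, with a range from 0.7 h to 3 h.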

Compound 3, half-life: 1.3 h
The estimate for compound 3 lay 1.2-fold (0.06 log units) above the measured number, and the stated range covers the measured number.
By their numbers in this assay, from the lowest: compounds 3, 1 and 2 (each within the scatter of the next).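

With benzyl in place of cyclopropyl on a saturated chain carbon bound to an aromatic carbon and a double-bonded chain carbon, this assay gives a 1.5-fold lower number from compound 1 to compound 3 (0.18 log units; within the scatter). Going by these compounds alone, this is the first one-place step in the set, and it shows that benzyl, with its 7 heavy atoms against the 3 of cyclopropyl, leaves a half-life that cannot be told apart from that of compound 1. Nothing in the data accounts for the size of this step.

Within the data shown here, this single step compares only two groups made of carbon alone, so it gives no trend for the position. From the compounds shown here alone, whether an amine or a carboxylic acid at this place would leave the half-life within the same scatter remains open.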